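Acetamido in place of acetoxy: an expected rise

The source may report more compounds than this note shows. Statements on the series, on what has been measured and on what is new or still open speak of the compounds shown alone.

- Compound 1 `O=c1cc(N2CCN(CC3CCC(NS(=O)(=O)c4ccccc4)CC3)CC2)sc2c([N+](=O)[O-])cc(C(F)(F)F)cc12`: 95.3%
- Compound 2 `CC(=O)OC1CCC(CN2CCN(c3cc(=O)c4cc(C(F)(F)F)cc([N+](=O)[O-])c4s3)CC2)CC1`: 0%

In an ADME assay on cells (Hepatocyte, Mus musculus) for metabolic stability, with a stated time of 30 min (on this read-out higher numbers stand for a more stable compound and lower numbers for a less stable compound), compound 2 stands lowest of the two measured compounds, at 0%. Compound 3 `CC(=O)NC1CCC(CN2CCN(c3cc(=O)c4cc(C(F)(F)F)cc([N+](=O)[O-])c4s3)CC2)CC1` differs from it in one place: acetamido in place of acetoxy on a saturated ring carbon. This puts acetamido in place of acetoxy on a saturated ring carbon. Within the data shown here, one measured step bears on this place, the large a number 95.3 percentage points lower from compound 1 to compound 2 (beyond the scatter), which lies beyond the scatter. Among the measured compounds shown here, no measured compound carries acetamido itself. Compound 3 keeps a nitrogen on that carbon, as compound 1 does at 95.3%. The expected change is a large rise, estimated as a number 70 percentage points higher from compound 2 to compound 3 (beyond the scatter). Compound 3 is estimated at 70%, within an expected range of 35% to 95%.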

Compound 3, percent of the compound remaining: 94.9%
Compound 3: the middle estimate sits 24.9 percentage points below what was measured, within the range that was stated.
By their numbers in this assay, from the lowest: compound 2; then compounds 3 and 1 (each within the scatter of the next).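

In this assay, acetamido in place of acetoxy on the saturated ring carbon gives a number 94.9 percentage points higher from compound 2 to compound 3 (beyond the scatter), so the low number of compound 2 does not carry over to an acyl group joined through nitrogen. Acetyl in place of phenylsulfonyl on the amine nitrogen gives a number 0.4 percentage points lower from compound 1 to compound 3 (within the scatter), so the two groups cannot be told apart on this read-out. Nothing at hand explains the gap between the acetoxy and acetamido compounds. The compounds shown leave open how a free amine or a methyl ether on this ring carbon would read.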